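A few compounds are considered here, and "the series" means these few. Any claim that something is new, unique, unknown or untested is made for them only; others in the source may bear on it.

Compound 1 `CCOC(=O)c1c(C)nc(-c2cccc(C#N)c2)n1O` is the unsubstituted member of a small series tested in a functional assay on a cell-free system (plasma, Oryctolagus cuniculus) for inhibition, with stated times of 5 min, 1 min and 6 min (on this read-out higher numbers stand for weaker inhibition and lower numbers for stronger inhibition), where compound 1 gives 17600 nM, the highest of the three numbers shown, though its gap to compound 3 stays within the scatter. Compound 2 `CCOC(=O)COn1c(-c2cccc(C#N)c2)nc(C)c1C(=O)OCC` carries (ethoxycarbonyl)methyl in place of hydrogen on an oxygen on an aromatic ring, and in this assay compound 2 gives 6800 nM. Compound 3 `CCOC(=O)c1c(C)nc(-c2cccc(C#N)c2)n1OCc1ccc(C(=O)OC)cc1` carries 4-(methoxycarbonyl)phenyl in place of ethoxycarbonyl on that chain carbon, and in this assay compound 3 gives 9470 nM. The step of a 2.6-fold lower number from compound 1 to compound 2 (0.41 log units; beyond the scatter) shows that occupying the oxygen lowers the number; the step of a 1.4-fold higher number from compound 2 to compound 3 (0.14 log units; within the scatter) shows that the exchange of the group on the chain carbon changes little.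

Compound 4 `CCOC(=O)c1c(C)nc(-c2cccc(C#N)c2)n1OCc1ccc([N+](=O)[O-])cc1` has not yet been measured. It differs from compound 1 by 4-nitrobenzyl in place of hydrogen on an oxygen on an aromatic ring. The step of a 2.6-fold lower number from compound 1 to compound 2 (0.41 log units; beyond the scatter) bears on it most directly, and compound 3 with its value of 9470 nM offers the closest structural precedent, since it also places a substituted benzyl group on the same oxygen. One therefore expects a lowering of about a 2.2-fold lower number from compound 1 to compound 4 (0.34 log units; beyond the scatter) in this assay. The estimate for compound 4 is 8000 nM, with a range from 3000 nM to 22000 nM.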

Compound 4, half-maximal inhibitory concentration: 8750 nM
Compound 4: middle estimate off by 1.1-fold (0.04 log units), on the low side; low and high end bracket the measured number.
By their numbers in this assay, from the lowest: compounds 2, 4, 3 and 1 (each within the scatter of the next, the first and the last beyond it).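

Placing 4-nitrobenzyl on the oxygen gives a 2.0-fold lower number from compound 1 to compound 4 (0.30 log units; within the scatter) in this assay, so this replacement for hydrogen does not separate from the unsubstituted compound, whereas the smaller (ethoxycarbonyl)methyl group does, with a 2.6-fold lower number from compound 1 to compound 2 (0.41 log units; beyond the scatter). The exchange on the aromatic carbon of the benzyl group, nitro in place of methoxycarbonyl, gives a 1.1-fold lower number from compound 3 to compound 4 (0.03 log units; within the scatter), and the step to 4-nitrophenyl on the chain carbon gives a 1.3-fold higher number from compound 2 to compound 4 (0.11 log units; within the scatter). Compounds 2, 3 and 4 therefore cannot be told apart in this assay, which adds a second substituted benzyl group and shows that the choice among these three groups on the chain carbon leaves the number within the scatter; nothing available explains these results, and no supporting data bear on them.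

The compounds shown leave open whether a plain benzyl group, or an amine or a carboxylic acid on its aromatic carbon, would give a number distinct from these. They also leave open whether a longer chain on the oxygen would move the number further from that of compound 1, and what changes to the nitrile or the ethyl ester, held constant throughout, would do.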